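The compounds below may be only part of what the source reports. "The series", "measured", "known", "first", "only" and "open" are said of these compounds alone.

Measured in an ADME assay on HEK293 cells (Homo sapiens) for cytotoxicity, read by MTT assay, with a stated time of 48 h; on this read-out lower numbers stand for stronger inhibition and higher numbers for weaker inhibition:

Compound 1 `COc1cc(NC(=O)c2ccc(Cl)cc2)ccc1NS(C)(=O)=O` gives > 250000 nM, which is a limit of the assay.
Compound 2 `COc1cc(NC(=O)c2cccc(C(F)(F)F)c2)ccc1NS(C)(=O)=O` gives > 250000 nM, which is a limit of the assay.
Compound 3 `CS(=O)(=O)Nc1ccc(NC(=O)c2ccc(Cl)cc2)cc1Cl` gives 167000 nM.

Compound 1 and compound 3 differ in one place: chloro in place of methoxy on an aromatic carbon. In this assay this change gave an at least 1.4-fold lower number from compound 1 to compound 3 (0.17 log units; that floor lies within the scatter). The floor on that step rests on (the limit of > 250000 nM in this assay, at which 2 of the 3 values shown sit), and compound 1 sits at that limit, so the true size of the step is not pinned down.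

Compound 2 and compound 1 differ by more than one group; the difference between the two cores is not broken down here. Compound 4 `CS(=O)(=O)Nc1ccc(NC(=O)c2cccc(C(F)(F)F)c2)cc1Cl` has not yet been measured in this assay. Among the measured compounds shown here, it arises from compound 2 by the same change as the one from compound 1 to compound 3: chloro in place of methoxy on an aromatic carbon.

In this assay compound 4 is expected to give 180000 nM, with a likely range from 90000 nM to 300000 nM. That means an expected step of an at least 1.3-fold lower number from compound 2 to compound 4 (0.14 log units; that floor lies within the scatter), which can be set beside the measured at least 1.4-fold lower number from compound 1 to compound 3 (0.17 log units; that floor lies within the scatter). This expectation rests on compound 3, which gives 167000 nM after the same change on its own core. It also rests on compound 2, whose value > 250000 nM is only a limit of the assay, so the result for compound 4 may itself come back as a limit rather than a number.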

Compound 4, half-maximal inhibitory concentration: > 250000 nM
Compound 4 gave a limit, no number; the forecaster's own chance of this, stated with the estimate: 45%; middle value at least 1.3-fold (0.14 log units) from the limit.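

In this assay, compound 2 and compound 4 both end at a limit rather than a number, so the step between them, chloro in place of methoxy, cannot be read: the limit of > 250000 nM in this assay, at which 3 of the 4 values shown sit. The compounds shown leave open where the true values of compound 2 and compound 4 lie, and whether this change shifts the number at all on the core of compound 2.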